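Butyl in place of tert-butyl: an expected cytotoxicity reading

This account rests on a few compounds, and the source may have more. Where it says the series, first, only, none or still open, it means among the compounds named here.

Compound 1 `O=C(/C=C/c1ccc([N+](=O)[O-])o1)c1ccc(N2CCCCC2)cc1`: 349000 nM
Compound 2 `CC(C)(C)c1ccc(C(=O)/C=C/c2ccc([N+](=O)[O-])s2)cc1`: > 100000 nM

Both compounds were tested in an ADME assay on Vero cells (Chlorocebus sabaeus) for cytotoxicity, read by resazurin assay, with a stated time of 72 h; on this read-out lower numbers stand for higher toxicity in this test and higher numbers for lower toxicity in this test. Compound 1 returned a true number there. Compound 2 stands at the limit of > 100000 nM in this assay, at which 1 of the 2 values shown sits, so its result is a limit and not a number.

The compound still awaiting measurement is compound 3 `CCCCc1ccc(C(=O)/C=C/c2ccc([N+](=O)[O-])s2)cc1`. It has the same atoms as compound 2, joined differently, with butyl in place of tert-butyl on an aromatic carbon, para to a large group: butyl in place of tert-butyl on an aromatic carbon.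

For the measured compounds named here, no measured pair here differs in one place, so the data offer no direct guide to the size of this change. No step beyond the usual scatter is expected in this assay, and so no clear direction either. This expectation leans on compound 2, whose result of > 100000 nM is a limit. The expected change is a step that the limit leaves unreadable from compound 2 to compound 3. Compound 3 may also return only a limit. For compound 3 the estimated value is 110000 nM, with an expected range from 40000 nM to 300000 nM.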

Compound 3, half-maximal cytotoxic concentration: 81300 nM
Beside the measured number, compound 3's estimate is 1.4-fold (0.13 log units) above it, and the stated range covers the measured number.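

In this assay, for the compounds shown here, compound 3 gives a true number for this position, 81300 nM, so a butyl on an aromatic carbon, para to a large group, now has a readable place on the scale, which the earlier compounds did not provide for this site. Butyl in place of tert-butyl gives an at least 1.2-fold lower number from compound 2 to compound 3 (0.08 log units; that floor lies within the scatter), so the change is bounded on one side only, and that floor alone does not establish a real difference between the two groups. Compound 2 remains a limit and not a number, which leaves the true size of the step unknown: the limit of > 100000 nM in this assay, at which 1 of the 3 values shown sits.

The compounds shown leave open how a shorter chain such as ethyl, a longer chain such as octyl, an amine or a carboxylic acid would read at this position on the shared core. They also leave open any wider reading of the site, since compound 1 differs from compound 3 in more than one place and offers no direct comparison.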